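The source may report more compounds than this note shows. Statements on the series, on what has been measured and on what is new or still open speak of the compounds shown alone.

Measured in a functional assay on MIA PaCa-2 cells (Homo sapiens) for inhibition, read by MTT assay; on this read-out higher numbers stand for weaker inhibition and lower numbers for stronger inhibition:

- compound 1 `CCC(CO)Nc1ncc2cc(C(=O)N(C)C)n(C3CCCC3)c2n1`: 31000 nM
- compound 2 `O=C(Nc1ccccc1)c1cc2cnc(Nc3ccccc3)nc2n1C1CCCC1`: 14000 nM
- compound 3 `O=C(c1cc2cnc(Nc3ccc(N4CCNCC4)cn3)nc2n1C1CCCC1)N1CCCCC1`: 39600 nM

Compound 3, at 39600 nM, lies within the scatter of compound 1 and stands at a higher number than compound 2, beyond the scatter. Compound 4 `O=C(Nc1ccccc1)c1cc2cnc(Nc3ccc(N4CCNCC4)cn3)nc2n1C1CCCC1` has anilino in place of piperidin-1-yl on a carbonyl carbon. Going by the values given here, no measured pair shows this change alone. Compound 2, which carries the same anilino on a carbonyl carbon but differs elsewhere, gives 14000 nM. A small step towards stronger inhibition is therefore expected in this assay, hardly beyond the scatter. The expected change is a 1.8-fold lower number from compound 3 to compound 4 (0.26 log units; within the scatter). For compound 4 the estimated value is 22000 nM, within an expected range of 7000 nM to 50000 nM.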

Compound 4, half-maximal inhibitory concentration: 2800 nM
Compound 4: middle estimate off by 7.9-fold (0.90 log units), on the high side; the whole stated range lies above it.
By their numbers in this assay, from the lowest: compound 4; then compound 2; then compounds 1 and 3 (each within the scatter of the next).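

In this assay, going by these compounds alone, anilino in place of piperidin-1-yl on a carbonyl carbon gives a 14-fold lower number from compound 3 to compound 4 (1.15 log units; beyond the scatter) and so matters far more with the 5-(piperazin-1-yl)pyridin-2-yl group present than the earlier compounds could show. With the anilino kept, 5-(piperazin-1-yl)pyridin-2-yl in place of phenyl on a nitrogen on an aromatic ring gives a 5.0-fold lower number from compound 2 to compound 4 (0.70 log units; beyond the scatter) as a further, smaller gain. Nothing at hand gives a reason for either step.

The compounds shown leave open whether benzylamino or cyclohexylamino on that carbonyl carbon would match anilino. They also leave open how a fluorine or methoxy group on the anilino ring would act.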